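The source may report more compounds than this note shows. Statements on the series, on what has been measured and on what is new or still open speak of the compounds shown alone.

Measured so far:
Compound 1, `CNC(=O)c1ccncc1Nc1cc(-c2ccc3ccn(C)c3c2)c2nccnc2c1`: 7020 nM
Compound 2, `CN1CCC(NC(=O)c2ccncc2Nc2cc(-c3ccc4ccn(C)c4c3)c3nccnc3c2)CC1=O`: 48800 nM
Compound 3, `Cn1ccc2ccc(-c3cc(Nc4cnccc4C(=O)NCC4COCCN4)cc4nccnc34)cc21`: 41700 nM

These three compounds were all tested in an assay on lysate for inhibition of 6-phosphofructo-2-kinase/fructose-2,6-bisphosphatase 3 (Homo sapiens), with stated times of 0.5 min and 45 min; on this read-out lower numbers stand for stronger inhibition and higher numbers for weaker inhibition. Compound 3 gives the second highest number of the three: its nearest neighbour is compound 2, as a 1.2-fold lower number from compound 2 to compound 3 (0.07 log units; within the scatter) shows, a gap within the scatter; its furthest is compound 1, with a 5.9-fold higher number from compound 1 to compound 3 (0.77 log units; beyond the scatter).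

Compound 4, `CC(=O)N1CC(CNC(=O)c2ccncc2Nc2cc(-c3ccc4ccn(C)c4c3)c3nccnc3c2)C1`, has not yet been measured. It differs from compound 3 in one place: 1-acetylazetidin-3-yl in place of morpholin-3-yl on a saturated chain carbon bound to an amide-type nitrogen. The two steps that bear on this are those that change the group on the amide-type nitrogen. Going from the small methyl to a larger ring-bearing group cost potency in both cases, a 7.0-fold higher number from compound 1 to compound 2 (0.84 log units; beyond the scatter) and a 5.9-fold higher number from compound 1 to compound 3 (0.77 log units; beyond the scatter), while exchanging one ring-bearing group for another, a 1.2-fold lower number from compound 2 to compound 3 (0.07 log units; within the scatter), made no difference beyond the scatter. Compound 4 again carries a ring-bearing group of similar size here, so the expected step from compound 3 is small, a 1.0-fold lower number from compound 3 to compound 4 (0.02 log units; within the scatter), in neither direction beyond the scatter. For compound 4 the estimated value in this assay is 40000 nM, with a range from 15000 nM to 110000 nM.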

Compound 4, half-maximal inhibitory concentration: > 100000 nM
Compound 4 gave a limit, no number; the forecaster's own chance of this, stated with the estimate: 10%; middle value at least 2.5-fold (0.39 log units) from the limit.
By their numbers in this assay, from the lowest: compound 1; then compounds 3 and 2 (each within the scatter of the next). At a limit, above all of these: compound 4.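

In this assay, compound 4 gives a limit and not a number: the limit of > 100000 nM in this assay, at which 1 of the 4 values shown sits.

Among the earlier compounds, exchanging one ring-bearing group for another on the amide-type nitrogen changed nothing beyond the scatter (a 1.2-fold lower number from compound 2 to compound 3 (0.07 log units; within the scatter)), so the position seemed indifferent to which ring it carried, but that no longer holds: there is an at least 2.3-fold higher number from compound 3 to compound 4 (0.37 log units; beyond the scatter), and also an at least 2.0-fold higher number from compound 2 to compound 4 (0.31 log units; beyond the scatter), both printed as beyond the scatter. Among the compounds shown here, measured against the small methyl group of compound 1, the new group gives the widest gap of the series so far, an at least 14-fold higher number from compound 1 to compound 4 (1.15 log units; beyond the scatter), which shows that the loss does not depend only on a ring-bearing group being present, but also on which one it is.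

From the compounds shown here alone, with only a limit for compound 4, the true size of these steps stays unknown, and the change alters several things at once: a six-membered ring gives way to a four-membered one, an acetyl group enters, and the hydrogen-bond donor of morpholin-3-yl is gone. Still open, going by these compounds, is whether azetidin-3-yl without the acetyl, with its ring amine free, or a plain ethyl group on the amide-type nitrogen would fall nearer to compound 1 or to compound 4.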